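Anilide change on the benzamide series

This account rests on a few compounds, and the source may have more. Where it says the series, first, only, none or still open, it means among the compounds named here.

Measured compounds:
compound 1 `Nc1ccccc1NC(=O)c1ccc(NCC(=O)Nc2cccc([N+](=O)[O-])c2)cc1` gives 13500 nM
compound 2 `COc1ccc(NC(=O)CNCCCC(=O)Nc2ccccc2N)cc1` gives 34000 nM

In a functional assay on U-251 cells (Homo sapiens) for inhibition, read by MTT assay, with a stated time of 2 days (on this read-out lower numbers stand for stronger inhibition of growth and higher numbers for weaker inhibition of growth), compound 1 gives the lower of the two numbers, and the gap to compound 2 lies beyond the scatter. The two measured compounds differ in more than one place, so no single step can be read from them. Compound 3 `Nc1ccccc1NC(=O)c1ccc(NCC(=O)Nc2ccc(Cl)cc2)cc1` differs from compound 1 by 4-chlorophenyl in place of 3-nitrophenyl on an amide-type nitrogen. Among the compounds with values here, no measured pair shows this change, so the expected step is small and its direction uncertain, a 1.1-fold higher number from compound 1 to compound 3 (0.05 log units; within the scatter). Compound 3 is expected to give about 15000 nM, within a range from 5000 nM to 45000 nM.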

Compound 3, concentration for 50% growth inhibition: 9400 nM
Compound 3: middle estimate off by 1.6-fold (0.20 log units), on the high side, and the stated range covers the measured number.
By their numbers in this assay, from the lowest: compounds 3 and 1 (each within the scatter of the next); then compound 2.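

Within the data shown here, on the amide-type nitrogen, 4-chlorophenyl in place of 3-nitrophenyl gives the first single-place step: in this assay the result is a 1.4-fold lower number from compound 1 to compound 3 (0.16 log units; within the scatter) and stays within the scatter. At this position, the two substituted phenyl groups therefore cannot be told apart on this read-out, despite the loss of the nitro group. No measurement shown gives a reason for this result.

As far as these compounds go, whether an unsubstituted phenyl, a cyclohexyl or a carboxylic acid on the phenyl ring would keep the number in this range remains open.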